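Methyl for trifluoromethyl: working notes on compound 4

The source may hold more compounds than are shown below. What is called first, only, known or untested is meant among the compounds shown, and "the series" means these compounds.

Of the compounds shown here, three on a shared core have been tested in a functional assay on HepG2 cells (Homo sapiens) for cytotoxicity, read by MTT assay, with a stated time of 72 h; a lower number here means a stronger inhibitor, a higher number a weaker inhibitor. Compound 1 `COc1ccc2ccc(=O)oc2c1C(/C=C/c1ccc(C(F)(F)F)cc1)=N/NC(N)=O` gives 96 nM in this assay. Compound 2 `COc1ccc2ccc(=O)oc2c1C1=NN(C(N)=O)C(c2ccc(SC)cc2)C1` gives 18 nM, and compound 3 `COc1ccc2ccc(=O)oc2c1C1=NNC(c2cccs2)C1` gives 11 nM. Compound 1 thus stands at the highest number of the three; compound 2 is the nearest, with a lower number that lies beyond the usual scatter, and compound 3 is the furthest, also beyond the scatter. Compounds 2 and 3 carry cyclised arrangements that compound 1 lacks, so no single-point comparison exists among the measured set.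

Compound 4 `COc1ccc2ccc(=O)oc2c1C(/C=C/c1ccc(C)cc1)=N/NC(N)=O` is the untested partner of compound 1. The change is methyl in place of trifluoromethyl on an aromatic carbon. For the measured compounds named here, no measured pair shows this exchange, so its size is not anchored by data. Both groups entering and leaving are uncharged, lack donors and acceptors, and sit at the same position, so the expected step is small and without a clear direction, likely within the scatter. The expected step is a 1.1-fold higher number from compound 1 to compound 4 (0.06 log units; within the scatter). For compound 4 the estimate in this assay is 110 nM, with a range from 40 nM to 300 nM.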

Compound 4, half-maximal inhibitory concentration: 93 nM
Estimate against measurement, compound 4: 1.2-fold (0.07 log units) above; measured number inside the range.
By their numbers in this assay, from the lowest: compounds 3 and 2 (each within the scatter of the next); then compounds 4 and 1 (each within the scatter of the next).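

In this assay, for the compounds shown here, methyl in place of trifluoromethyl on an aromatic carbon gives a 1.0-fold lower number from compound 1 to compound 4 (0.01 log units; within the scatter), the first single-point step. At this place, para to a large group, 4-(trifluoromethyl)phenyl and 4-methylphenyl therefore cannot be told apart in this read-out, even though the group leaving and the group entering differ in heavy-atom count and in the presence of fluorine. No measurement is available that explains why the two groups read alike.

Still open, as far as these compounds go, is whether an amine, a carboxylic acid or a longer chain at this same place would also stay within the scatter of compound 1. Also open, from the compounds shown here alone, is whether the exchange of trifluoromethyl for methyl would read the same way on the cyclised arrangements of compound 2 and compound 3.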